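Turning One Ring Stereocentre from R to S

This account rests on a few compounds, and the source may have more. Where it says the series, first, only, none or still open, it means among the compounds named here.

In a physicochemical assay for lipophilicity, at pH 7.4 (on this read-out higher numbers stand for higher lipophilicity and lower numbers for lower lipophilicity), compound 1 (`CCc1ccc(N(CC(C)C)S(=O)(=O)c2ccc3c(c2)C(O)CC(C2CCOCC2)O3)cc1`) gives 4.12 and compound 2 (`CCc1ccc(N(CC(C)C)S(=O)(=O)c2ccc3c(c2)C(O)C[C@H](C2CCOCC2)O3)cc1`) gives 4.12 as well, so compound 2 stands level with compound 1. Not yet measured, compound 3 (`CCc1ccc(N(CC(C)C)S(=O)(=O)c2ccc3c(c2)C(O)C[C@@H](C2CCOCC2)O3)cc1`) differs from compound 2 by the two compounds have the same atoms and bonds; at least one stereo element is drawn with a configuration in one of them and without one in the other: 1 of 2 stereo elements differ; a stereocentre at a saturated ring carbon is drawn R in compound 2 and S in compound 3 and nothing leaves or enters: a stereocentre at a saturated ring carbon is drawn R in compound 2 and S in compound 3. Going by the values given here, the one measured step that bears on this, at the same carbon, shows no change at the digits printed from compound 1 to compound 2 (within the scatter) and the fact that one of compounds 1 and 2 is drawn with a defined configuration and the other without, at the place where they differ is the only difference there. On that small step, no shift in either direction beyond the scatter is expected in this assay for this inversion. The expected step is no change at the digits printed from compound 2 to compound 3 (within the scatter) and it would stay within the scatter. Compound 3 is estimated at 4.12 with 3.85 to 4.4 as its expected range.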

Compound 3, distribution coefficient: 4.12
Compound 3: the middle estimate sits on the measured number at the digits printed; the range from low to high includes it.
By their numbers in this assay, from the lowest: compounds 1, 2 and 3 (each within the scatter of the next).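

In this assay, the inversion of the stereocentre at the saturated ring carbon from R to S reads as no change at the digits printed from compound 2 to compound 3 (within the scatter), and the S form set against the drawing without a configuration reads as no change at the digits printed from compound 1 to compound 3 (within the scatter). The earlier compounds shown here held only the R form, so this position now shows that both drawn configurations stand level with each other and with the drawing without a configuration. The structures of the second pair part only at that carbon: the fact that one of compounds 1 and 3 is drawn with a defined configuration and the other without, at the place where they differ

Open, as far as these compounds go, is how the other stereocentre, drawn without a configuration in all three compounds, bears on this assay. Also open, from the compounds shown here alone, is whether the two configurations would stay level with an amine or a carboxylic acid in place of the group on this carbon.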